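This account rests on a few compounds, and the source may have more. Where it says the series, first, only, none or still open, it means among the compounds named here.

Measured in a functional assay on MIA PaCa-2 cells (Homo sapiens) for cytotoxicity, read by WST assay, with a stated time of 24 h; a lower number here means a stronger inhibitor, a higher number a weaker inhibitor:
Compound 1 `N#C/C(=C\c1cn(Cc2ccc(Cl)cc2)c2ccccc12)C(=O)c1c[nH]c2cc(F)ccc12`: > 50000 nM
Compound 2 `COc1ccc2c(C(=O)/C(C#N)=C/c3cn(Cc4ccc(Cl)cc4)c4ccccc34)c[nH]c2c1`: > 50000 nM
Compound 3 `COc1ccc(Cn2cc(/C=C(\C#N)C(=O)c3c[nH]c4cc(OC)ccc34)c3ccccc32)cc1`: > 50000 nM

None of these is a number, and the evidence amounts to the limit of > 50000 nM in this assay, at which 3 of the 3 values shown sit. Compound 3 gives only the limit > 50000 nM. Compound 4 `COc1ccc(Cn2cc(/C=C(\C#N)C(=O)c3c[nH]c4cc(F)ccc34)c3ccccc32)cc1` carries fluoro in place of methoxy on an aromatic carbon, changing 6-methoxy-1H-indol-3-yl to 6-fluoro-1H-indol-3-yl: fluoro in place of methoxy on an aromatic carbon. The closest measured change is the reverse exchange, a step that the two limits leave unreadable from compound 1 to compound 2. The other, methoxy in place of chloro, is a step that the two limits leave unreadable from compound 2 to compound 3. Neither gives a size to carry over, so no step beyond the scatter is expected, and a result at the limit again seems likely. The expected change is a number no higher from compound 3 to compound 4 (the limit leaves the size open). Compound 4 is estimated at 50000 nM, within an expected range of 20000 nM to 100000 nM.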

Compound 4, half-maximal inhibitory concentration: > 50000 nM
Compound 4 was reported as a limit; the forecaster's own chance of this, stated with the estimate: 80%; the middle value lies on the limit itself.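

Compound 4 stops at a limit, as do compound 1 and compound 3, so neither step from those compounds to compound 4 can be read. The compounds shown leave open how strong any of them really is in this assay, and whether exchanging these groups changes that: the limit of > 50000 nM in this assay, at which 4 of the 4 values shown sit.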